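This account rests on a few compounds, and the source may have more. Where it says the series, first, only, none or still open, it means among the compounds named here.

Measured so far in a functional assay on KB cells (Homo sapiens) for inhibition, read by sulforhodamine B assay; on this read-out lower numbers stand for stronger inhibition of growth and higher numbers for weaker inhibition of growth:
- compound 1 `Cc1ccc2[nH]c(-c3ccc(-c4ccc(-c5cccc(Cl)c5)cc4)cc3)nc2c1` gives 2260 nM
- compound 2 `Oc1ccc(-c2ccc(-c3ccc(-c4nc5ccccc5[nH]4)cc3)cc2)cc1` gives 41000 nM

Compound 2 has the higher of the two numbers, and its gap to compound 1 lies beyond the scatter. Compound 3 `Clc1cccc(-c2ccc(-c3ccc(-c4nc5ccccc5[nH]4)cc3)cc2)c1` has not yet been measured. Its difference from compound 2 is 3-chlorophenyl in place of 4-hydroxyphenyl on an aromatic carbon with 3-chlorophenyl in place of 4-hydroxyphenyl on an aromatic carbon, para to a large group. Among the measured compounds shown here, no step between measured compounds is available to size this change directly. Compound 1 also carries 3-chlorophenyl and gives 2260 nM so a clearly lower number is expected in this assay for the new compound, beyond the scatter. The expected move is a 14-fold lower number from compound 2 to compound 3 (1.14 log units; beyond the scatter) toward stronger inhibition of growth. For compound 3 the estimate is 3000 nM with an expected range from 1000 nM to 9000 nM as the working figures.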

Compound 3, concentration for 50% growth inhibition: 32300 nM
Compound 3: middle estimate off by 11-fold (1.03 log units), on the low side, and the stated range ends below it.
By their numbers in this assay, from the lowest: compound 1; then compounds 3 and 2 (each within the scatter of the next).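

In this assay putting 3-chlorophenyl in place of 4-hydroxyphenyl at this position makes no difference that can be read (a 1.3-fold lower number from compound 2 to compound 3 (0.10 log units; within the scatter)), although the entering group has 0 hydrogen-bond donors and the leaving group has 1. The 3-chlorophenyl group alone therefore does not account for the value of compound 1, since hydrogen in place of methyl on an aromatic carbon is a large step (a 14-fold higher number from compound 1 to compound 3 (1.16 log units; beyond the scatter)). No measurement here bears on the reason for either result.

As far as these compounds go, it remains open whether the methyl step holds with 4-hydroxyphenyl in place of 3-chlorophenyl. Also open, from the compounds shown here alone, is whether ethyl, methoxy or chlorine on the carbon that carries the methyl in compound 1 would give a similar step, and whether an amine or a carboxylic acid would be tolerated in place of 3-chlorophenyl.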